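The source may report more compounds than this note shows. Statements on the series, on what has been measured and on what is new or still open speak of the compounds shown alone.

Working notes on the series. The shared core of compound 3 `CCOC(=O)c1c(N)sc(/N=C/c2ccc(C)cc2)c1C(=O)OCC` is carried unchanged through compound 1 `CCOC(=O)c1c(N)sc(/N=C/c2ccc(N(C)C)cc2)c1C(=O)OCC` and compound 2 `CCOC(=O)c1c(N)sc(/N=C/c2ccc(OC)cc2)c1C(=O)OCC`; the three differ only in the group on the aromatic carbon para to the large group. In a functional assay on Ishikawa cells (Homo sapiens) for inhibition, read by MTT assay, with a stated time of 48 h (a higher number here means a weaker inhibitor, a lower number a stronger inhibitor), compound 1 gives 73000 nM, compound 2 gives 108000 nM and compound 3 gives 52500 nM. Compound 3 thus has the lowest of the three numbers, although its step to compound 1 lies within the scatter, so only the gap to compound 2 counts as a real difference.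

The next step replaces the group at that same place once more: bromo in place of methyl on an aromatic carbon, giving compound 4 `CCOC(=O)c1c(N)sc(/N=C/c2ccc(Br)cc2)c1C(=O)OCC`. The measured steps that bear on it are all swaps at this one position: a 1.5-fold higher number from compound 1 to compound 2 (0.17 log units; within the scatter), a 1.4-fold lower number from compound 1 to compound 3 (0.14 log units; within the scatter) and a 2.1-fold lower number from compound 2 to compound 3 (0.31 log units; beyond the scatter). Two of these sit within the scatter and the third is only modest. Nothing in the series involves bromo, so the direction cannot be read from the data; the expectation is a step no larger than those seen, and probably none beyond the scatter, in this assay.

Compound 4 is therefore estimated at 50000 nM, within 20000 nM to 125000 nM, an expected step of a 1.1-fold lower number from compound 3 to compound 4 (0.02 log units; within the scatter).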

Compound 4, half-maximal inhibitory concentration: 46100 nM
For compound 4 the middle estimate is 1.1-fold (0.04 log units) above the measured one, and the stated range covers the measured number.
By their numbers in this assay, from the lowest: compounds 4, 3, 1 and 2 (each within the scatter of the next, the first and the last beyond it).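

In this assay, among the compounds shown here, bromo is the first group at this position that is not built on carbon, nitrogen or oxygen, and it can't be told apart from methyl, with a 1.1-fold lower number from compound 3 to compound 4 (0.06 log units; within the scatter). Nor does it separate clearly from dimethylamino, with a 1.6-fold lower number from compound 1 to compound 4 (0.20 log units; within the scatter), but it does separate from methoxy, with a 2.3-fold lower number from compound 2 to compound 4 (0.37 log units; beyond the scatter), so compound 2 now stands apart from both compound 3 and compound 4, while compound 1 stays within the scatter of all three. No supporting measurement accounts for these steps.

The compounds shown leave open whether a hydroxyl, a carboxylic acid, a primary amine or a longer alkyl chain in place of bromo would move the number further than any step seen here, or whether this position stays as flat as these four compounds suggest. They also leave open whether the small gap around methoxy holds with a chloro or fluoro group on the same aromatic carbon, and whether the ethyl esters of the shared core matter more than this position does.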